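The compounds below may be only part of what the source reports. "The series", "measured", "known", "first", "only" and "open" are said of these compounds alone.

Compound 1 `COc1ccc(S(=O)(=O)Nc2ccc(-c3nc4ccccc4o3)cc2)cc1`: in an assay on cells for inhibition of HSP60/HSP10 (Homo sapiens), with a stated time of 60 min (on this read-out lower numbers stand for stronger inhibition and higher numbers for weaker inhibition), compound 1 gives > 100000 nM, which is a limit of the assay and not a number.
Compound 2 `C=Cc1ccc(S(=O)(=O)Nc2ccc(-c3nc4ccccc4o3)cc2)cc1`: compound 2 gives > 100000 nM, again a limit rather than a number.
Compound 3 `O=S(=O)(Nc1ccc(-c2nc3ccccc3o2)cc1)c1cccc(O)c1`: compound 3 gives 62000 nM.

Compound 3 thus holds the only number shown; the two other values sit at the limit of > 100000 nM in this assay, at which 2 of the 3 values shown sit. Compound 4 `O=S(=O)(Nc1ccc(-c2nc3ccccc3o2)cc1)c1ccccc1F` differs from compound 3 at one place: 2-fluorophenyl in place of 3-hydroxyphenyl on a sulfonyl sulfur. Among the compounds with values here, the steps that bear on this are an at least 1.6-fold lower number from compound 1 to compound 3 (0.20 log units; that floor lies within the scatter) and an at least 1.6-fold lower number from compound 2 to compound 3 (0.20 log units; that floor lies within the scatter), both leading to the hydroxyl-bearing compound 3 from compounds at the limit. Removing the 3-hydroxyphenyl in favour of the 2-fluorophenyl is therefore expected to move the number back up, likely to the limit. Compound 4 is estimated at 100000 nM, within 40000 nM to 300000 nM, an expected step of a 1.6-fold higher number from compound 3 to compound 4 (0.21 log units; within the scatter).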

Compound 4, half-maximal inhibitory concentration: > 100000 nM
Compound 4: no number, only a limit (the forecaster's own chance of this, stated with the estimate: 60%); the middle value sits exactly at the limit.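

Compound 4 gives only a limit in this assay, not a number. The swap of 3-hydroxyphenyl for 2-fluorophenyl therefore reads only as an at least 1.6-fold higher number from compound 3 to compound 4 (0.20 log units; that floor lies within the scatter). The 2-fluorophenyl, with no hydrogen-bond donor or acceptor, is the third group on the sulfonyl sulfur to end at that ceiling, and its steps from compound 1 and compound 2 cannot be read: the limit of > 100000 nM in this assay, at which 3 of the 4 values shown sit.

Within the data shown here, compound 3 remains the only compound with a number, so it stays open whether that number depends on its hydroxyl. A phenyl carrying an amine or a carboxylic acid at this place could test this.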